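The compounds below may be only part of what the source reports. "The series", "measured", "known", "first", "only" and "open" are said of these compounds alone.

Measured compounds:
- Compound 1, `COc1ccc(OC)c(-c2cc(-c3ccc(Cl)cc3)nn2-c2ccccc2)c1`: in a functional assay on cells (Cancer cell lines, Homo sapiens) for cytotoxicity, read by sulforhodamine B assay, with a stated time of 48 h (a lower number here means a stronger inhibitor of growth, a higher number a weaker inhibitor of growth), compound 1 gives 78600 nM.
- Compound 2, `COc1ccc(OC)c(-c2cc(-c3ccc(Cl)cc3)nn2-c2ccc(S(=O)(=O)NC(C)=O)cc2)c1`: in this assay compound 2 gives 70200 nM.

Among the compounds with values here, compound 2 holds the lower of the two numbers so far in this assay, but its nearest neighbour is compound 1, and the gap between them is within the scatter. Within the data shown here, the only step measured, a 1.1-fold lower number from compound 1 to compound 2 (0.05 log units; within the scatter), concerns the phenyl ring on the nitrogen of the shared core and did not move the number beyond the scatter.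

Compound 3, `CC(=O)NS(=O)(=O)c1ccc(-n2nc(-c3ccc(Cl)cc3)cc2-c2cc(O)ccc2O)cc1`, differs from compound 2 at another place: 2,5-dihydroxyphenyl in place of 2,5-dimethoxyphenyl on an aromatic carbon. Among the measured compounds shown here, no measured step touches this position, so the one step recorded gives no direct guidance on the size or direction of the change. In the absence of such a step, a number close to that of compound 2 is the plainest expectation, with a wide margin to either side.

Compound 3 is therefore expected to give about 60000 nM in this assay, most likely between 20000 nM and 180000 nM. The step this estimate implies, a 1.2-fold lower number from compound 2 to compound 3 (0.07 log units; within the scatter), is expected to remain within the scatter.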

Compound 3, concentration for total growth inhibition: 82100 nM
Estimate against measurement, compound 3: 1.4-fold (0.14 log units) below, and the stated range covers the measured number.
By their numbers in this assay, from the lowest: compounds 2, 1 and 3 (each within the scatter of the next).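

At this position, on an aromatic carbon of the five-membered ring next to the ring nitrogen, 2,5-dihydroxyphenyl in place of 2,5-dimethoxyphenyl gives, in this assay, a 1.2-fold higher number from compound 2 to compound 3 (0.07 log units; within the scatter). Within the data shown here, this is the first measured change on this aryl group, and it shows that exchanging a group with no hydrogen-bond donors for one that has them, while also going from the larger group to the smaller, leaves the number of compound 3 within the scatter of that of compound 2, just as a 1.1-fold lower number from compound 1 to compound 2 (0.05 log units; within the scatter) did at the phenyl ring on the nitrogen. No measurement given here offers an explanation for this result.

From the compounds shown here alone, whether this position stays as unresponsive with a different kind of substituent remains open, for instance an amine, a carboxylic acid or a longer alkoxy chain such as butoxy on this aryl ring. Among these compounds, the 4-chlorophenyl group is also untouched by any step so far, so what a bromine or a methyl group in place of its chlorine would do in this assay is unknown.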